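This account rests on a few compounds, and the source may have more. Where it says the series, first, only, none or still open, it means among the compounds named here.

In a functional assay on the whole organism (stomach) for inhibition, with Rattus norvegicus as the target (a higher number here means that more compound is needed for the effect, a lower number that less compound is needed), compound 1 `O=C(O)CCC/C=C1\CC2C[C@@H](O)[C@H](/C=C/[C@@H](O)C3Cc4ccccc4C3)C2C1` gives 0.0562 mg/kg. Compound 2 `O=C(O)CCC/C=C1\CC2C[C@@H](O)[C@H](/C=C/[C@@H](O)C3Cc4ccc(Cl)cc4C3)C2C1` stands only at a limit, > 0.3 mg/kg. Compound 3 `CC1([C@H](O)/C=C/[C@@H]2C3C/C(=C/CCCC(=O)O)CC3C[C@H]2O)Cc2ccccc2C1` differs from it by 2-methyl-2,3-dihydro-1H-inden-2-yl in place of 5-chloro-2,3-dihydro-1H-inden-2-yl on a saturated chain carbon bound to a double-bonded chain carbon and an oxygen on a saturated carbon. For the measured compounds named here, the one measured step that bears on this is an at least 5.3-fold higher number from compound 1 to compound 2 (0.72 log units; beyond the scatter), with chloro in place of hydrogen on an aromatic carbon, so losing that chloro is expected to take back much of it, though no measured step covers the methyl. The expected change, toward a lower number, is an at least 3.0-fold lower number from compound 2 to compound 3 (0.47 log units; beyond the scatter). The estimate for compound 3 is 0.1 mg/kg, with an expected range of 0.025 mg/kg to 0.4 mg/kg.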

Compound 3, dose for half-maximal effect: 0.0452 mg/kg
The estimate for compound 3 lay 2.2-fold (0.34 log units) above the measured number, and the stated range covers the measured number.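

A methyl in place of hydrogen on this saturated ring carbon is accommodated in this assay, with a 1.2-fold lower number from compound 1 to compound 3 (0.09 log units; within the scatter). Replacing 5-chloro-2,3-dihydro-1H-inden-2-yl with 2-methyl-2,3-dihydro-1H-inden-2-yl gives an at least 6.6-fold lower number from compound 2 to compound 3 (0.82 log units; beyond the scatter), so the unchlorinated, methylated group retains the standing of the unsubstituted one. The size of that step is only a minimum, as compound 2 stands at a limit: the limit of > 0.3 mg/kg in this assay, at which 1 of the 3 values shown sits.

From the compounds shown here alone, what ethyl or hydroxymethyl would do on that saturated ring carbon stays open. So does whether fluoro or methoxy on the aromatic carbon would behave like chloro.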